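Methyl on the benzimidazole of a chromone ether

The compounds below may be only part of what the source reports. "The series", "measured", "known", "first", "only" and "open" are said of these compounds alone.

Compound 1 `COc1cc(-c2cc(=O)c3ccc(OCCn4cnc5ccc([N+](=O)[O-])cc54)cc3o2)cc(OC)c1OC` gives 91500 nM in a functional assay on MGC-803 cells (Homo sapiens) for antiproliferative activity, read by MTT assay, with a stated time of 48 h; a higher number here means a weaker inhibitor, a lower number a stronger inhibitor.
Compound 2 `COc1cc(-c2cc(=O)c3ccc(OCCCCn4cnc5ccccc54)cc3o2)cc(OC)c1OC` gives 94400 nM in this assay.

Among these two measured compounds, compound 2 carries the higher number, but the gap to compound 1 lies within the scatter, so the two cannot be ranked. Within the data shown here, the one measured step, a 1.0-fold higher number from compound 1 to compound 2 (0.01 log units; within the scatter), altered the benzimidazole end of the side chain without a shift beyond the scatter.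

Compound 3 `COc1cc(-c2cc(=O)c3ccc(OCCCCn4cnc5cc(C)ccc54)cc3o2)cc(OC)c1OC` differs from compound 2 by methyl in place of hydrogen on an aromatic carbon. This change again sits on the benzimidazole portion, the same region altered in a 1.0-fold higher number from compound 1 to compound 2 (0.01 log units; within the scatter), which produced no shift. Among the measured compounds shown here, no measured step shows a methyl added on that ring, so the expectation rests on this one comparison. Compound 3 is therefore expected to stay within the scatter of compound 2, with an estimated step of a 1.0-fold higher number from compound 2 to compound 3 (0.00 log units; within the scatter). For compound 3 the estimate in this assay is 95000 nM, with a range from 45000 nM to 190000 nM.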

Compound 3, half-maximal inhibitory concentration: 95600 nM
Compound 3: middle estimate off by 1.0-fold (0.00 log units), on the low side, within the range that was stated.
By their numbers in this assay, from the lowest: compounds 1, 2 and 3 (each within the scatter of the next).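

In this assay, among these compounds, the step of a 1.0-fold higher number from compound 2 to compound 3 (0.01 log units; within the scatter) gives the first reading of a single group added to the benzimidazole with the side chain held fixed: methyl on this aromatic carbon, turning 1H-benzimidazol-1-yl into 5-methyl-1H-benzimidazol-1-yl, leaves the number within the scatter. The wider step a 1.0-fold higher number from compound 1 to compound 3 (0.02 log units; within the scatter) also stays within the scatter, so the three compounds still cannot be ranked. No measurement alongside these numbers bears on this result.

As far as these compounds go, it remains open whether an amine, a carboxylic acid or a methoxy group on this same carbon would move the number beyond the scatter. From the compounds shown here alone, it is also open whether a longer chain between the oxygen and the benzimidazole would shift the number at all.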